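The compounds below may be only part of what the source reports. "The series", "measured", "known", "first", "only" and "open" are said of these compounds alone.

Three related amides have been tested in an in vitro assay on HEK-tsA201 cells for antagonist activity at Neuronal acetylcholine receptor; alpha4/beta2 (Homo sapiens), read by fluorescence and calcium flux; on this read-out higher numbers stand for weaker inhibition and lower numbers for stronger inhibition. Compound 2, `CCCOc1ccc(C(=O)Nc2cccc(CC)n2)cc1`, carries a propoxy group and an ethyl group on its two rings; in this assay compound 2 gives 37600 nM. Compound 1, `C=CCOc1ccc(C(=O)Nc2cccc(CC)n2)cc1`, differs from it only by vinyl in place of ethyl on a saturated chain carbon bound to an oxygen on an aromatic ring; in this assay compound 1 gives 20500 nM, which makes the step of a 1.8-fold lower number from compound 2 to compound 1 (0.26 log units; within the scatter). Compound 3, `CCCNc1cccc(NC(=O)c2ccc(OCCC)cc2)n1`, keeps the propoxy group of compound 2 but differs on the other ring, where the counted difference is propylamino in place of ethyl on an aromatic carbon; in this assay compound 3 gives 15400 nM, a step of a 2.4-fold lower number from compound 2 to compound 3 (0.39 log units; beyond the scatter).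

Compound 4, `C=CCOc1ccc(C(=O)Nc2cccc(NCCC)n2)cc1`, has not yet been measured. Among the compounds with values here, it differs from compound 3 by vinyl in place of ethyl on a saturated chain carbon bound to an oxygen on an aromatic ring, which is the same change, at the same place, as the one that turned compound 2 into compound 1. The two cores on which the change is made differ from each other in the way just described for compound 3 against compound 2.

Because that earlier change gave a 1.8-fold lower number from compound 2 to compound 1 (0.26 log units; within the scatter), a step of similar size is expected here: the step from compound 3 to compound 4 is expected to be a 1.6-fold lower number from compound 3 to compound 4 (0.21 log units; within the scatter), a shift that stays within the usual scatter of repeated measurements. In this assay compound 4 is therefore estimated at 9500 nM, with a likely range from 4000 nM to 22000 nM.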

Compound 4, half-maximal inhibitory concentration: 14800 nM
For compound 4 the middle estimate is 1.6-fold (0.19 log units) below the measured one; low and high end bracket the measured number.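

Carrying the change from propoxy to allyloxy onto the core of compound 3 gives a 1.0-fold lower number from compound 3 to compound 4 (0.02 log units; within the scatter), while the change from ethyl to propylamino, read on the core of compound 1, gives a 1.4-fold lower number from compound 1 to compound 4 (0.14 log units; within the scatter). The propoxy to allyloxy change therefore gives no difference between the two cores that can be told from the scatter, although the step is too small on both cores to show a clear effect of its own: the same change on two cores in this assay, a 1.8-fold lower number (0.26 log units; within the scatter) from compound 2 to compound 1 and a 1.0-fold lower number (0.02 log units; within the scatter) from compound 3 to compound 4, 1.8-fold (0.25 log units) apart, within the scatter of two such steps. The ethyl to propylamino step is beyond the scatter on one core and within it on the other, but this does not show that the step truly weakens on the allyloxy core, and two cores cannot show that either change carries over throughout the series: the same change on two cores in this assay, a 2.4-fold lower number (0.39 log units; beyond the scatter) from compound 2 to compound 3 and a 1.4-fold lower number (0.14 log units; within the scatter) from compound 1 to compound 4, 1.8-fold (0.25 log units) apart, within the scatter of two such steps.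

The four compounds leave open whether the same agreement would hold for other groups on the oxygen, such as a butyl chain or a cyclopropylmethyl group, or for a carboxylic acid in place of the propylamino group. Also open, on these data alone, is whether a change with a much larger step would carry over as closely between these two cores.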